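Swapping the thienyl ketone of compound 1 for benzoyl

The compounds below may be only part of what the source reports. "The series", "measured", "known", "first", "only" and "open" are said of these compounds alone.

Compound 1 `COc1cc(-c2nnc3n2NC(c2ccco2)C(C(=O)c2cccs2)S3)cc(OC)c1OC` is tested in a functional assay on MCF7 cells (Homo sapiens) for cytotoxicity, read by MTT assay, with a stated time of 48 h; on this read-out higher numbers stand for weaker inhibition and lower numbers for stronger inhibition. For compound 1 the read-out of > 100000 nM is a limit of the assay, not a number (the limit of > 100000 nM in this assay, at which 1 of the 3 values shown sits). Compound 2 `COc1cc(-c2nnc3n2NC(c2cccs2)C(C(=O)c2ccc(C)cc2)S3)cc(OC)c1OC` gives 28400 nM in this assay, and compound 3 `COc1cc(C(=O)C2Sc3nnc(-c4cc(OC)c(OC)c(OC)c4)n3NC2c2cccs2)cc(OC)c1OC` gives 71000 nM. Going by the values given here, the one measured step at the carbonyl carbon, a 2.5-fold higher number from compound 2 to compound 3 (0.40 log units; beyond the scatter), shows that changing the aryl group there shifts the number only modestly. Compound 4 `COc1cc(-c2nnc3n2NC(c2ccco2)C(C(=O)c2ccccc2)S3)cc(OC)c1OC` differs from compound 1 by phenyl in place of thiophen-2-yl on a carbonyl carbon. Among the compounds with values here, no measured step covers phenyl against thiophen-2-yl at this place, and the expectation rests on compound 1 standing at its limit (the limit of > 100000 nM in this assay, at which 1 of the 3 values shown sits). Compound 4 is therefore expected to stay near that limit, a number no higher from compound 1 to compound 4 (the limit leaves the size open), with an estimated 100000 nM and a range from 35000 nM to 300000 nM.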

Compound 4, half-maximal inhibitory concentration: 39800 nM
The estimate for compound 4 lay 2.5-fold (0.40 log units) above the measured number; low and high end bracket the measured number.
By their numbers in this assay, from the lowest: compounds 2, 4 and 3 (each within the scatter of the next, the first and the last beyond it). At a limit, above all of these: compound 1.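

Changing the group on the carbonyl carbon can move a compound on the core of compound 1 off the limit and onto a measured number: in this assay, phenyl in place of thiophen-2-yl gives an at least 2.5-fold lower number from compound 1 to compound 4 (0.40 log units; beyond the scatter). The earlier step at this place joined two measured numbers and did not show this. For compound 1 the read-out is a limit, so only a smallest size of the step can be read: the limit of > 100000 nM in this assay, at which 1 of the 4 values shown sits.

All the groups shown on this carbonyl carbon are aromatic rings. Going by these compounds, whether an amine or a short alkyl chain there would give a measured number stays open.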